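The source may hold more compounds than are shown below. What is called first, only, known or untested is meant among the compounds shown, and "the series" means these compounds.

Measured so far in a physicochemical assay for lipophilicity; on this read-out higher numbers stand for higher lipophilicity and lower numbers for lower lipophilicity:
compound 1 `C/C=C/C=C/C(=O)Nc1cccc([N+](=O)[O-])c1` gives 2.49
compound 2 `C/C=C/C=C/C(=O)NCC` gives 1.19
compound 3 `C/C=C/C=C/C(=O)OC(C)CC` gives 2.72

Compound 3 (2.72) is the starting point for the next step. Compound 1 (2.49) lies within the scatter of compound 3, whereas compound 2 (1.19) lies lower than compound 3, beyond the scatter.

Compound 4 `C=CCOC(=O)/C=C/C=C/C` has not yet been measured. It carries allyl in place of sec-butyl on an oxygen next to a carbonyl group and otherwise matches compound 3. Among the measured compounds shown here, the three measured compounds offer no pair that differs in one place, so no measured step guides this change. The expectation therefore rests only on compound 3 (2.72) and the structural change. In this assay a moderate fall is expected, probably beyond the scatter, although a result within the scatter of compound 3 cannot be excluded. The estimated move is a number 0.57 log units lower from compound 3 to compound 4 (beyond the scatter) and remains an expectation until a measurement is available. Compound 4 is expected at 2.15 with an estimated range of 1.85 to 2.45 for now.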

Compound 4, partition coefficient: 2.24
The estimate for compound 4 lay 0.09 log units below the measured number, and the stated range covers the measured number.
By their numbers in this assay, from the lowest: compound 2; then compounds 4, 1 and 3 (each within the scatter of the next, the first and the last beyond it).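

In this assay, allyl in place of sec-butyl on an oxygen next to a carbonyl group gives a number 0.48 log units lower from compound 3 to compound 4 (beyond the scatter), and this is the only step shown between compounds that differ in one place. Among the compounds shown here, it therefore gives this position a measured response that the earlier compounds could not provide: the group on this oxygen can move the read-out beyond the scatter while the rest of the structure stays the same. For the compounds shown here, no measured information on the origin of this step is available, and the exchange of sec-butyl, with 4 heavy atoms, for allyl, with 3 heavy atoms and 1 double bond outside aromatic rings, alters both features at once, so the single pair does not separate them.

Still open, on these data alone, is how propyl, which would keep the chain of allyl without its double bond, would read at this oxygen, and whether a longer chain such as n-hexyl would move the number the other way. Equally open, as far as these compounds go, is whether the same exchange of sec-butyl for allyl gives a step of similar size on a different core, or whether a benzyl group or an amine-bearing chain at this oxygen departs from it.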